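Pyrazin-2-yl for Pyridin-3-yl on the Ring Nitrogen of Compound 1

The compounds below may be only part of what the source reports. "The series", "measured", "known", "first", "only" and "open" are said of these compounds alone.

Measured compounds in a functional assay on HeLa cells (Homo sapiens) for antiproliferative activity, read by CCK-8 assay, with a stated time of 72 h, tested at 2 uM; on this read-out higher numbers stand for a stronger effect at the one concentration tested and lower numbers for a weaker effect:
Compound 1 `Nc1ccccc1NC(=O)c1ccc(CSC(=S)N2CCN(c3cccnc3)CC2)cc1` gives 66.2%.
Compound 2 `Nc1ccccc1NC(=O)c1ccc(CSC(=S)N2CCc3cc(Cl)ccc32)cc1` gives 40.1%.
Compound 3 `Nc1ccccc1NC(=O)c1ccc(CSC(=S)N2CCCC2)cc1` gives 51.3%.

Compound 1 stands highest of the three, beyond the scatter from both compound 3 and compound 2. Going by the values given here, the one step among the measured compounds, a number 11.2 percentage points higher from compound 2 to compound 3 (beyond the scatter), concerns the group on the thiocarbonyl carbon and so tells nothing about the aryl group on the ring nitrogen.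

Compound 4 `Nc1ccccc1NC(=O)c1ccc(CSC(=S)N2CCN(c3cnccn3)CC2)cc1` differs from compound 1 by pyrazin-2-yl in place of pyridin-3-yl on an amine nitrogen in a ring. Among the compounds with values here, no measured pair shows this change, so the expectation rests on compound 1 alone, with the step of a number 11.2 percentage points higher from compound 2 to compound 3 (beyond the scatter) only indicating how much a single substitution elsewhere on the same core has moved the read-out. Compound 4 is therefore expected to stay near compound 1, with an estimated step of a number 5.2 percentage points lower from compound 1 to compound 4 (within the scatter), not clearly beyond the scatter in either direction. The estimate for compound 4 is 61%, within a range from 46% to 76%.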

Compound 4, a percentage reported as inhibition, at one concentration (the size of the read-out at that concentration, not a potency): 70.4%
For compound 4 the middle estimate is 9.4 percentage points below the measured one; the measured number falls inside the stated range.
By their numbers in this assay, from the lowest: compound 2; then compound 3; then compounds 1 and 4 (each within the scatter of the next).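

In this assay, going by these compounds alone, placing pyrazin-2-yl where pyridin-3-yl stood on the amine nitrogen in a ring gives a number 4.2 percentage points higher from compound 1 to compound 4 (within the scatter), the first reading at this position. The aromatic ring here can therefore carry 2 hetero atoms in place of 1 without a read-out that can be told apart from that of the pyridin-3-yl compound, so the high level seen earlier is not confined to pyridin-3-yl. Nothing available here indicates why the two groups read alike.

As far as these compounds go, whether a plain phenyl ring or a small alkyl group such as methyl on this nitrogen would hold the read-out remains open. With a single concentration, the compounds shown also leave open whether the two aryl groups would still read alike at other concentrations.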